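This account rests on a few compounds, and the source may have more. Where it says the series, first, only, none or still open, it means among the compounds named here.

Measured so far:
- Compound 1 `C/C=C/COc1cc(/C=C\c2cc(OC)c(OC)c(OC)c2)ccc1OC`: 135000 nM
- Compound 2 `COc1ccc(/C=C\c2cc(OC)c(OC)c(OC)c2)cc1OCc1ccccc1`: 15000 nM
- Compound 3 `COc1cccc(/C=C/CCCOc2cc(/C=C\c3cc(OC)c(OC)c(OC)c3)ccc2OC)c1`: 39000 nM

In an ADME assay on HEK293 cells (Homo sapiens) for inhibition, read by MTT assay, with a stated time of 3 days (on this read-out higher numbers stand for weaker inhibition and lower numbers for stronger inhibition), compound 3 gives 39000 nM, the middle of the three numbers. Compound 2 lies lower at 15000 nM, and compound 1 lies higher at 135000 nM.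

Compound 4 `COc1ccc(/C=C/CCCOc2cc(/C=C\c3cc(OC)c(OC)c(OC)c3)ccc2OC)cc1` has the same atoms as compound 3, joined differently: 4-methoxyphenyl in place of 3-methoxyphenyl on a double-bonded chain carbon bound to a double-bonded chain carbon.

Three measured steps offer indirect guidance. Each exchanges a whole group on the chain carbon bound to the ring oxygen, and all are modest: a 9.0-fold lower number from compound 1 to compound 2 (0.95 log units; beyond the scatter), a 3.5-fold lower number from compound 1 to compound 3 (0.54 log units; beyond the scatter) and a 2.6-fold higher number from compound 2 to compound 3 (0.41 log units; beyond the scatter). None of them compares a 3-methoxyphenyl with a 4-methoxyphenyl, so the data give no direct guide to direction. The new change leaves the group's counted make-up the same, so a smaller step than these seems likely.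

The expected result in this assay is a 1.1-fold lower number from compound 3 to compound 4 (0.03 log units; within the scatter), with no step beyond the scatter anticipated. The estimate for compound 4 is 36000 nM, with an expected range from 14000 nM to 90000 nM.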

Compound 4, half-maximal inhibitory concentration: 88000 nM
For compound 4 the middle estimate is 2.4-fold (0.39 log units) below the measured one; the range from low to high includes it.
By their numbers in this assay, from the lowest: compound 2; then compound 3; then compounds 4 and 1 (each within the scatter of the next).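

In this assay, 4-methoxyphenyl in place of 3-methoxyphenyl gives a 2.3-fold higher number from compound 3 to compound 4 (0.35 log units; beyond the scatter) even though the two groups count the same atoms, so at this position the way the atoms are joined matters, not only which atoms are present. The longer group also loses its separation from the small prop-1-en-1-yl group, shown by a 1.5-fold lower number from compound 1 to compound 4 (0.19 log units; within the scatter) in this form, while phenyl keeps the lower number, with a 5.9-fold higher number from compound 2 to compound 4 (0.77 log units; beyond the scatter) as the step. No measurement shown here explains why the two methoxyphenyl groups differ.

The compounds shown leave open whether a hydroxyl or an amine in place of the methoxy would move the number in either direction. They also leave open whether a longer chain would change how the two methoxyphenyl groups compare.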